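This account rests on a few compounds, and the source may have more. Where it says the series, first, only, none or still open, it means among the compounds named here.

Compound 3 `O=c1nc2ccccn2cc1Cc1ccc(F)cc1` carries a fluoro on the benzyl ring. Within the data shown here, in a functional assay on SK-N-SH cells (Homo sapiens) for cytotoxicity, read by MTT assay, with a stated time of 24 h (on this read-out lower numbers stand for stronger inhibition and higher numbers for weaker inhibition), compound 3 gives 125000 nM, which is the second highest of the three numbers known so far. Among the measured compounds shown here, its nearest neighbour is compound 1 `O=c1nc2ccccn2cc1Cc1ccc(Br)cc1`, which gives 163000 nM; the step of a 1.3-fold lower number from compound 1 to compound 3 (0.12 log units; within the scatter) is the only single-place step measured and concerns the benzyl ring, not the core. Far away stands compound 2 `Cc1ccc(Cc2cn3cc(Cl)ccc3nc2=O)cc1`, which gives 860 nM; compound 2 differs from compound 3 in two places at once, a chloro on the core and a methyl on the benzyl ring, so its low number cannot be tied to either change alone.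

Compound 4 `O=c1nc2ccc(Cl)cn2cc1Cc1ccc(F)cc1` arises from compound 3 by chloro in place of hydrogen on an aromatic carbon. For the measured compounds named here, no measured step covers chloro in place of hydrogen on the core, so the expectation rests on the gap between compound 3 and compound 2, both of which share the same chloro on the core. Compound 4 is therefore expected to give a markedly lower number, a step of a 50-fold lower number from compound 3 to compound 4 (1.70 log units; beyond the scatter), with the estimate for compound 4 being 2500 nM and a range from 400 nM to 25000 nM.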

Compound 4, half-maximal inhibitory concentration: 9860 nM
Estimate against measurement, compound 4: 3.9-fold (0.60 log units) below, within the range that was stated.
By their numbers in this assay, from the lowest: compound 2; then compound 4; then compounds 3 and 1 (each within the scatter of the next).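

Chloro in place of hydrogen on the core, two atoms from the ring nitrogen, now stands as a single change in this assay with the benzyl fluoro held constant, and it gives a 13-fold lower number from compound 3 to compound 4 (1.10 log units; beyond the scatter) as a step beyond the scatter. With the chloro held constant, the benzyl ring also counts on this core, since the change gives an 11-fold higher number from compound 2 to compound 4 (1.06 log units; beyond the scatter) as a second step beyond the scatter, so the chloro alone does not reach the low number of compound 2. No measured evidence accounts for either step.

On these data alone, whether the chloro step keeps its size with bromo or methyl on the benzyl ring remains open. So does how a methoxy group or an amine at the same place on the core would compare with chloro.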